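The compounds below may be only part of what the source reports. "The series", "measured", "known", "first", "only" and "open" are said of these compounds alone.

Compound 3 `COc1ccc(-c2ccc(OCc3cc(C(=O)NS(=O)(=O)c4ccc(C)cn4)oc3C)cc2)cc1` sits second highest of the three numbers recorded in an assay on cells for displacement of a labelled ligand from prostaglandin E2 receptor EP4 subtype (Homo sapiens), read by scintillation counting (on this read-out higher numbers stand for weaker inhibition and lower numbers for stronger inhibition), where compound 3 gives 15 nM. Its nearest neighbour is compound 1 `COc1ccc(-c2ccc(OCc3cc(C(=O)NS(=O)(=O)c4cccs4)oc3C)cc2)cc1`, which in this assay gives 3.6 nM, and the step of a 4.2-fold higher number from compound 1 to compound 3 (0.62 log units; beyond the scatter) is beyond the scatter. Furthest from it is compound 2 `COc1ccc(-c2ccc(OCc3cc(C(=O)NS(=O)(=O)c4ccc(CN)cc4)oc3C)cc2)cc1`, which gives 100 nM; the step of a 6.7-fold lower number from compound 2 to compound 3 (0.82 log units; beyond the scatter) is also beyond the scatter, as is the step of a 28-fold higher number from compound 1 to compound 2 (1.44 log units; beyond the scatter).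

Compound 4 `COc1ccc(-c2ccc(OCc3cc(C(=O)NS(=O)(=O)Cc4ccccc4)oc3C)cc2)cc1` differs from compound 3 in one place: benzyl in place of 5-methylpyridin-2-yl on a sulfonyl sulfur. All three measured steps exchange the group on the sulfonyl sulfur, so they bear on this change, though each of them swaps one aromatic ring directly bound to the sulfur for another, whereas here a benzyl enters. Going by the values given here, those steps ranged from modest to large in this assay, and none of the measured compounds carries a benzyl on the sulfonyl sulfur, so there is no direct precedent. A modest step toward a higher number is expected because a 4.2-fold higher number from compound 1 to compound 3 (0.62 log units; beyond the scatter) and a 6.7-fold lower number from compound 2 to compound 3 (0.82 log units; beyond the scatter) show that swaps at this position usually move the number beyond the scatter. Compound 4 is therefore estimated at 40 nM, between 8 nM and 200 nM, which means an expected step of a 2.7-fold higher number from compound 3 to compound 4 (0.43 log units; beyond the scatter).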

Compound 4, inhibition constant: 3 nM
Compound 4: the middle estimate sits 13-fold (1.12 log units) above what was measured; the whole stated range lies above it.
By their numbers in this assay, from the lowest: compounds 4 and 1 (each within the scatter of the next); then compound 3; then compound 2.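

The earlier compounds shown here all carried an aromatic ring directly on the sulfonyl sulfur, and compound 4 shows that this direct attachment is not needed for a low number in this assay: benzyl gives a 5.0-fold lower number from compound 3 to compound 4 (0.70 log units; beyond the scatter) and a 33-fold lower number from compound 2 to compound 4 (1.52 log units; beyond the scatter). Against thiophen-2-yl the same change gives a 1.2-fold lower number from compound 1 to compound 4 (0.08 log units; within the scatter), so the two groups cannot be told apart here, and the low number at this position no longer rests on compound 1 alone. Nothing available explains why benzyl behaves so differently from 5-methylpyridin-2-yl.

The compounds shown leave open whether the ring needs to be present at all, as a plain butyl chain on the sulfonyl sulfur would test, and whether a longer chain such as 2-phenylethyl holds the low number that benzyl gives. They also leave open how substituents on the benzyl ring would read, for example a methoxy group, a fluorine or the aminomethyl group that compound 2 carries on its phenyl ring.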